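Halogen swap on the phenoxy arm of compound 2

The compounds below may be only part of what the source reports. "The series", "measured", "known", "first", "only" and "open" are said of these compounds alone.

Measured compounds:
compound 1, `N[C@@H](COP(=O)(O)OCCCOC(=O)CCc1ccccc1OCc1cccc(OC2CCCCC2)c1)C(=O)O`, 18.8%
compound 2, `N[C@@H](COP(=O)(O)OCCCOC(=O)CCc1ccccc1OCc1cccc(Oc2cccc(Cl)c2)c1)C(=O)O`, 17.1%

Both compounds share one core and differ only in the group on an oxygen on an aromatic ring. In an assay on cells for agonist activity at probable G-protein coupled receptor 34 (Mus musculus), with a stated time of 1 h (on this read-out higher numbers stand for larger maximal responses and lower numbers for smaller maximal responses), compound 1 gives 18.8%, and in this assay compound 2 gives 17.1%. For the measured compounds named here, the one step measured so far, a number 1.7 percentage points lower from compound 1 to compound 2 (within the scatter), shows that compound 2 and compound 1 sit within the scatter of each other, so neither can be set above the other on these numbers.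

Compound 3, `N[C@@H](COP(=O)(O)OCCCOC(=O)CCc1ccccc1OCc1cccc(Oc2ccc(I)cc2)c1)C(=O)O`, has not yet been measured. It differs from compound 2 by 4-iodophenyl in place of 3-chlorophenyl on an oxygen on an aromatic ring.

Going by the values given here, the only measured step that bears on this place is a number 1.7 percentage points lower from compound 1 to compound 2 (within the scatter), and that exchange of a whole group for another gave no step beyond the scatter. A change from one halogenated phenyl to another at the same place gives no ground to expect more. Compound 3 is therefore expected to give 17%, with a range from 8% to 28%. The step that this estimate means, a number 0.1 percentage points lower from compound 2 to compound 3 (within the scatter), is expected to remain within the scatter.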

Compound 3, largest response reached (Emax), in percent of the reference or control that the assay uses: 19.1%
Estimate against measurement, compound 3: 2.1 percentage points below, within the range that was stated.
By their numbers in this assay, from the lowest: compounds 2, 1 and 3 (each within the scatter of the next).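

In this assay the exchange of 3-chlorophenyl for 4-iodophenyl on an oxygen on an aromatic ring comes to a number 2 percentage points higher from compound 2 to compound 3 (within the scatter), so this change of both the halogen and its numbered place on the phenyl ring does not separate the two compounds. Against the cyclohexyl group, the 4-iodophenyl group comes to a number 0.3 percentage points higher from compound 1 to compound 3 (within the scatter), so the three groups now tested at this place cannot be told apart on this read-out, whether the ring is aromatic or not. Nothing measured here offers an explanation for this sameness.

As far as these compounds go, since the halogen and its numbered place change together between compound 2 and compound 3, the effect of each alone remains open, and a 4-chlorophenyl group at the same place would be needed to tell them apart. From the compounds shown here alone, it also remains open whether a group of another kind on this oxygen, such as an amine or a carboxylic acid on a longer chain, would give a number beyond the scatter of these three.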